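This account rests on a few compounds, and the source may have more. Where it says the series, first, only, none or still open, it means among the compounds named here.

Measured in a functional assay on MCF7 cells (Homo sapiens) for antiproliferative activity, read by sulforhodamine B assay, with a stated time of 48 h; on this read-out lower numbers stand for stronger inhibition and higher numbers for weaker inhibition:
Compound 1 `O=C1NCCN1c1ccc(S(=O)(=O)Nc2ccc(C3CCCCC3)cc2)cc1`: > 1000 nM, a limit
Compound 2 `O=C1NCCN1c1ccc(S(=O)(=O)Nc2ccc(I)cc2)cc1`: 600 nM
Compound 3 `CC(C)(C)c1ccc(NS(=O)(=O)c2ccc(N3CCNC3=O)cc2)cc1`: > 1000 nM, a limit

Compound 3 has no number of its own in this assay, only the limit > 1000 nM. The series meets (the limit of > 1000 nM in this assay, at which 2 of the 3 values shown sit), and compound 2 alone gives a number.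

Compound 4 `O=C1NCCN1c1ccc(S(=O)(=O)Nc2ccc(OC(F)F)cc2)cc1` carries difluoromethoxy in place of tert-butyl on an aromatic carbon, para to a large group: difluoromethoxy in place of tert-butyl on an aromatic carbon.

Among the measured compounds shown here, two measured steps bear on this change, since each exchanges a group on an aromatic carbon: an at least 1.6-fold higher number from compound 2 to compound 3 (0.22 log units; that floor lies within the scatter) and an at least 1.6-fold lower number from compound 1 to compound 2 (0.22 log units; that floor lies within the scatter). Both are known only as floors, and those floors lie within the scatter. The third, a step that the two limits leave unreadable from compound 1 to compound 3, gives no size at all. The evidence for any gain is therefore thin. It rests on compound 2, at 600 nM, which shows that a group other than tert-butyl or cyclohexyl can bring a number within the range of the assay. A modest lowering is expected in this assay, not one clearly beyond the scatter, and a result at the limit remains quite possible. The expected step is an at least 1.1-fold lower number from compound 3 to compound 4 (0.04 log units; that floor lies within the scatter). For compound 4 the estimated value is 900 nM, with an expected range from 300 nM to 2500 nM.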

Compound 4, half-maximal inhibitory concentration: 760 nM
Estimate against measurement, compound 4: 1.2-fold (0.07 log units) above; the measured number falls inside the stated range.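

Compound 4 is only the second compound in this assay to give a number rather than a limit, which shows that this place, on an aromatic carbon para to a large group, can carry difluoromethoxy as well as iodo and still give a reading. Difluoromethoxy in place of tert-butyl gives an at least 1.3-fold lower number from compound 3 to compound 4 (0.11 log units; that floor lies within the scatter), and in place of cyclohexyl it gives an at least 1.3-fold lower number from compound 1 to compound 4 (0.11 log units; that floor lies within the scatter), and both steps remain floors because one partner in each pair sits at a limit: the limit of > 1000 nM in this assay, at which 2 of the 4 values shown sit. The exchange of iodo for difluoromethoxy is the first step in the series that rests on two actual numbers, and it gives a 1.3-fold higher number from compound 2 to compound 4 (0.10 log units; within the scatter), so two groups with entirely different atoms cannot be told apart in this assay.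

The compounds shown leave open whether any group at this place can bring the number clearly beyond the scatter of compound 2 and compound 4. A methoxy group set against difluoromethoxy, or chloro, an amine or a carboxylic acid at the same place, would show how much of the reading depends on the fluorine atoms or on the group at all.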